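A few compounds are considered here, and "the series" means these few. Any claim that something is new, unique, unknown or untested is made for them only; others in the source may bear on it.

The series shares one core; compound 1 is `N#Cc1c(-c2ccc(Cl)cc2)c(C#N)c(=O)n(/N=C/c2cn(-c3ccccc3)nc2-c2ccccc2)c1N` and compound 2 is `N#Cc1c(-c2ccc(F)cc2)c(C#N)c(=O)n(/N=C/c2cn(-c3ccccc3)nc2-c2ccccc2)c1N`. In an ADME assay on NIH3T3 cells (Mus musculus) for cytotoxicity, read by MTT assay (on this read-out higher numbers stand for weaker inhibition and lower numbers for stronger inhibition), compound 1 gives 64 ug/mL. In this assay compound 2 reaches only a limit of the assay, > 200 ug/mL. Among the measured compounds shown here, the single measured step, an at least 3.1-fold higher number from compound 1 to compound 2 (0.49 log units; beyond the scatter), shows that a change at this aromatic carbon moved the number, although the size of that step rests on the limit of > 200 ug/mL in this assay, at which 1 of the 2 values shown sits, and is known only as a lower bound.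

Compound 3 is `COc1ccc(-c2c(C#N)c(N)n(/N=C/c3cn(-c4ccccc4)nc3-c3ccccc3)c(=O)c2C#N)cc1`; its change from compound 2 is methoxy in place of fluoro on an aromatic carbon. For the measured compounds named here, no measured step swaps fluoro for methoxy, so the chloro-to-fluoro step is the only guide and bears on it loosely. With compound 2 already at the limit, the number for compound 3 is expected to stay near it, the estimated step being a number no higher from compound 2 to compound 3 (the limit leaves the size open), and a limit rather than a number is the likelier report. The estimate for compound 3 in this assay is 200 ug/mL, ranging from 80 ug/mL to 500 ug/mL.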

Compound 3, half-maximal inhibitory concentration: 50 ug/mL
Compound 3: the middle estimate sits 4.0-fold (0.60 log units) above what was measured; measured number below the stated range.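

In this assay, methoxy in place of fluoro gives an at least 4.0-fold lower number from compound 2 to compound 3 (0.60 log units; beyond the scatter), so the high number for the 4-fluorophenyl group does not extend to the 4-methoxyphenyl group. Chloro and methoxy read alike at this position, with a 1.3-fold lower number from compound 1 to compound 3 (0.11 log units; within the scatter), which leaves fluoro as the one group of the three that stands apart. The step away from fluoro has a known lower bound but no known size: the limit of > 200 ug/mL in this assay, at which 1 of the 3 values shown sits.

Three groups at one position cannot show whether the shared level of chloro and methoxy is typical here, with fluoro as the exception, or whether the spread is wider. As far as these compounds go, an amine or a carboxylic acid on the same aromatic carbon would test this, and the rest of the shared core stays unexplored in these compounds.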